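This account rests on a few compounds, and the source may have more. Where it says the series, first, only, none or still open, it means among the compounds named here.

Compound 1 `S=C(SCc1cn(Cc2ccc(Cl)c(Cl)c2)nn1)N1CCNCC1` belongs to the same family as the pair followed here, but in a functional assay on PC-3 cells (Homo sapiens) for inhibition, read by MTT assay, with a stated time of 72 h (a higher number here means a weaker inhibitor, a lower number a stronger inhibitor), compound 1 has "not determined" (no result reported), so it offers no number to lean on. Compound 2 `CC(C)(C)OC(=O)N1CCN(C(=S)SCc2cn(Cc3ccc(Cl)cc3)nn2)CC1` carries a tert-butoxycarbonyl group on an amine nitrogen in a ring. In this assay compound 2 reaches only > 128000 nM, which is a limit of the assay and not a measured number. On the numbers shown, compound 2 therefore stands at the edge of what the assay can report: the limit of > 128000 nM in this assay, at which 1 of the 2 values shown sits, while the other entry carries no single number at all. Compound 3 `S=C(SCc1cn(Cc2ccc(Cl)cc2)nn1)N1CCNCC1` differs from compound 2 in one place: hydrogen in place of tert-butoxycarbonyl on an amine nitrogen in a ring. Among the compounds with values here, no step between two measured compounds is available, so the size of this change can only be guessed. In this assay the expected step is an at least 1.6-fold lower number from compound 2 to compound 3 (0.20 log units; that floor lies within the scatter), a small move toward stronger inhibition that is unlikely to exceed the usual scatter. Compound 3 is thus estimated at 80000 nM in this assay, within a range from 20000 nM to 250000 nM, with a real chance that only a limit is again reported.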

Compound 3, half-maximal inhibitory concentration: > 128000 nM
Compound 3: a limit, no number; the forecaster's own chance of this, stated with the estimate: 55%; middle value at least 1.6-fold (0.20 log units) from the limit.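

In this assay compound 3 gives > 128000 nM, which is a limit of the assay and not a number. Compound 2 also gives only a limit, so the step between these two compounds cannot be read. The compounds shown leave open whether hydrogen in place of tert-butoxycarbonyl changes inhibition at all, and the results stop at one edge: the limit of > 128000 nM in this assay, at which 2 of the 3 values shown sit.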